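Amide nitrogen substituent change from compound 3 to compound 4

A few compounds are considered here, and "the series" means these few. Any claim that something is new, unique, unknown or untested is made for them only; others in the source may bear on it.

Of the compounds shown here, three sharing one core have been measured in a functional assay on the whole organism (strain Wistar) for inhibition, with Rattus norvegicus as the target, read by paw edema, with stated times of 30 min and 1 h, at a dose of 20 mg/kg; a higher number here means more inhibition at the dose given (going by the name of the read-out), a lower number less inhibition. Compound 1 `CCOC(=O)C1=C(C)NC(C)=C(C(=O)OCC)C1c1ccc(OCC(=O)Nc2ccc(C)cc2)cc1` gives 55.1%. Compound 2 `CCOC(=O)C1=C(C)NC(C)=C(C(=O)OCC)C1c1ccc(OCC(=O)Nc2nc3ccccc3s2)cc1` gives 54.5%. Compound 3 `CCOC(=O)C1=C(C)NC(C)=C(C(=O)OCC)C1c1ccc(OCC(=O)NNC(=O)c2sccc2Cl)cc1` gives 39.7%, the lowest of the three numbers; its gaps to the other two, a number 15.4 percentage points lower from compound 1 to compound 3 (beyond the scatter) and a number 14.8 percentage points lower from compound 2 to compound 3 (beyond the scatter), both lie beyond the scatter, whereas a number 0.6 percentage points lower from compound 1 to compound 2 (within the scatter) does not.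

Compound 4 `CCOC(=O)C1=C(C)NC(C)=C(C(=O)OCC)C1c1ccc(OCC(=O)NN2C(=O)c3ccccc3C2=O)cc1` differs from compound 3 at the same amide-type nitrogen: a group of 11 heavy atoms (8 carbon, 1 nitrogen, 2 oxygen; one five-membered non-aromatic ring with 1 hetero atom, one six-membered aromatic ring of carbon only) in place of a group of 9 heavy atoms (5 carbon, 1 nitrogen, 1 oxygen, 1 sulfur, 1 chlorine; one five-membered aromatic ring with 1 hetero atom), on an amide-type nitrogen.

Among the compounds with values here, only two measured steps touch this position, and both ran from an aryl group on the nitrogen to a nitrogen-linked acyl group, with a modest fall each time. Within the data shown here, no step yet connects two nitrogen-linked groups, so nothing measured shows whether the new group recovers what compound 3 lost. Compound 4 keeps the nitrogen-linked arrangement of compound 3, so a step of about a number 2.3 percentage points higher from compound 3 to compound 4 (within the scatter) is expected, within the scatter. Compound 4 is therefore estimated at 42%, with a range from 28% to 56%.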

Compound 4, a percentage reported as inhibition, in the whole organism at one dose (the size of the read-out at that dose, not a potency): 42.3%
The estimate for compound 4 lay 0.3 percentage points below the measured number, within the range that was stated.
By their numbers in this assay, from the lowest: compounds 3 and 4 (each within the scatter of the next); then compounds 2 and 1 (each within the scatter of the next).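

In this assay, within the data shown here, a number 2.6 percentage points higher from compound 3 to compound 4 (within the scatter) gives the first reading between two nitrogen-linked groups on the amide-type nitrogen, and the swap from ((3-chlorothiophen-2-yl)carbonyl)amino to the group with one five-membered non-aromatic ring and one six-membered aromatic ring does not recover what compound 3 lost. The gap to the aryl-type groups persists, with a number 12.2 percentage points lower from compound 2 to compound 4 (beyond the scatter) and a number 12.8 percentage points lower from compound 1 to compound 4 (beyond the scatter), so the modest fall now holds for both nitrogen-linked groups, and the difference in hydrogen-bond donors between the two groups comes with no change beyond the scatter. No measurement is available that bears on the reason for this result.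

Open, going by these compounds, is whether the fall extends to nitrogen-linked groups generally or belongs to these two. A plain amino or acetylamino group on the amide-type nitrogen would test this.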